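Aryl variation on the fused core: nitro analogue

The source may hold more compounds than are shown below. What is called first, only, known or untested is meant among the compounds shown, and "the series" means these compounds.

Three aryl groups on the shared core have been measured. Compound 1 `CC(c1ccc(-c2ccccc2)c(F)c1)c1nnc2n1N=C(c1ccc(Cl)cc1)CS2` gives 8700 nM in a functional assay on MCF7 cells (Homo sapiens) for inhibition, read by sulforhodamine B assay, with a stated time of 72 h; a higher number here means a weaker inhibitor, a lower number a stronger inhibitor. Compound 2 `CC(c1ccc(-c2ccccc2)c(F)c1)c1nnc2n1N=C(c1ccc(C(F)(F)F)cc1)CS2` gives 4300 nM, and compound 3 `CC(c1ccc(-c2ccccc2)c(F)c1)c1nnc2n1N=C(c1ccc(Cl)cc1Cl)CS2` gives 7600 nM. Compound 3 stands second highest of the three numbers, within the scatter of both compound 1 and compound 2. The change to compound 4 `CC(c1ccc(-c2ccccc2)c(F)c1)c1nnc2n1N=C(c1ccc([N+](=O)[O-])cc1)CS2` is 4-nitrophenyl in place of 2,4-dichlorophenyl on a carbon with a double bond to nitrogen. Steps bearing on it: a 2.0-fold lower number from compound 1 to compound 2 (0.31 log units; beyond the scatter), a 1.1-fold lower number from compound 1 to compound 3 (0.06 log units; within the scatter) and a 1.8-fold higher number from compound 2 to compound 3 (0.25 log units; within the scatter). Going by the values given here, no measured step involves a nitro group, so the only guide is the modest spread among the aryl changes measured so far; no step beyond the scatter in this assay is expected. Compound 4 is therefore estimated at 6500 nM, with a range of 2500 nM to 16000 nM. This estimate means a 1.2-fold lower number from compound 3 to compound 4 (0.07 log units; within the scatter).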

Compound 4, half-maximal inhibitory concentration: 7800 nM
For compound 4 the middle estimate is 1.2-fold (0.08 log units) below the measured one, within the range that was stated.
By their numbers in this assay, from the lowest: compounds 2, 3, 4 and 1 (each within the scatter of the next, the first and the last beyond it).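

In this assay, 4-nitrophenyl on the carbon with a double bond to nitrogen stays within the scatter of all three earlier aryl groups: against 2,4-dichlorophenyl (a 1.0-fold higher number from compound 3 to compound 4 (0.01 log units; within the scatter)), against the chloro analogue (a 1.1-fold lower number from compound 1 to compound 4 (0.05 log units; within the scatter)) and against the trifluoromethyl analogue (a 1.8-fold higher number from compound 2 to compound 4 (0.26 log units; within the scatter)). Going by these compounds alone, this is the first aryl group here with hydrogen-bond acceptors, and they bring no step beyond the scatter. Nothing available explains this result.

On these data alone, whether an amine or a carboxylic acid on the aryl ring would also stay within the scatter remains open.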